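Cytotoxicity notes: anilino series, hydroxyethyl in place of thiazolylmethyl

The source may hold more compounds than are shown below. What is called first, only, known or untested is meant among the compounds shown, and "the series" means these compounds.

Measured compounds in an ADME assay on BaF3 cells (Mus musculus) for cytotoxicity; a lower number here means that less compound is needed, a higher number that more compound is needed for the effect:
compound 1 `Cc1nc(C)c(Cn2ncc3c(Nc4ccc(OC(F)(F)F)cc4)ncnc32)s1` — > 10000 nM
compound 2 `CCNC(=O)c1cc2c(Nc3ccc(OC(F)(F)F)cc3)ncnc2s1` — > 10000 nM
compound 3 `FC(F)(F)Oc1ccc(Nc2cc(-n3ccnc3)ncn2)cc1` — > 10000 nM

Compound 1 gives only a limit of the assay in this assay, > 10000 nM. Compound 2 likewise gives only a limit, > 10000 nM. Compound 3 also gives only a limit, > 10000 nM. So compound 1 stands nowhere distinct: all three values sit at the limit of > 10000 nM in this assay, at which 3 of the 3 values shown sit, and no step between measured compounds can be sized.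

Compound 4 `OCCn1ncc2c(Nc3ccc(OC(F)(F)F)cc3)ncnc21` differs from compound 1 by hydroxymethyl in place of 2,4-dimethyl-1,3-thiazol-5-yl on a saturated chain carbon bound to an aromatic nitrogen. With every measured value at the limit, no direction is expected for the step from compound 1 to compound 4 beyond the scatter, and the estimated step is a step that the limit leaves unreadable from compound 1 to compound 4. Compound 4 is expected at 15000 nM, within 5000 nM to 50000 nM, most likely reported again as a limit.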

Compound 4, half-maximal effective concentration: > 10000 nM
Compound 4: no number, only a limit; the forecaster's own chance of this, stated with the estimate: 80%; the middle value does not contradict the limit.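

Compound 1 and compound 4 both give only a limit in this assay, so no step can be read between them: the limit of > 10000 nM in this assay, at which 4 of the 4 values shown sit.

The compounds shown leave open whether (2,4-dimethyl-1,3-thiazol-5-yl)methyl to 2-hydroxyethyl changes the effective concentration at all.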